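Varying the amine on the ether chain of a coumarin amide

The source may hold more compounds than are shown below. What is called first, only, known or untested is meant among the compounds shown, and "the series" means these compounds.

Compound 1 `CCN(C)CCCOc1ccc2cc(NC(=O)c3ccc(O)c(CC=C(C)C)c3)c(=O)oc2c1C`: 730 nM
Compound 2 `CCCNCCCOc1ccc2cc(NC(=O)c3ccc(O)c(CC=C(C)C)c3)c(=O)oc2c1C`: 990 nM
Compound 3 `CC(C)=CCc1cc(C(=O)Nc2cc3ccc(OCCCNCC(C)C)c(C)c3oc2=O)ccc1O`: 1030 nM

In a functional assay on SK-BR-3 cells (Homo sapiens) for antiproliferative activity (on this read-out higher numbers stand for weaker inhibition and lower numbers for stronger inhibition), compound 3 gives the highest of the three numbers, but its separation from compound 2 and from compound 1 lies within the scatter, so the three amines cannot be ranked. Compound 4 `CC(C)=CCc1cc(C(=O)Nc2cc3ccc(OCCCNc4ccccc4)c(C)c3oc2=O)ccc1O` differs from compound 3 in one place: phenyl in place of isobutyl on an amine nitrogen. Among the compounds with values here, the steps that bear on this are the earlier exchanges at the same nitrogen, a 1.4-fold higher number from compound 1 to compound 3 (0.15 log units; within the scatter) and a 1.0-fold higher number from compound 2 to compound 3 (0.02 log units; within the scatter), both within the scatter. Those changes kept a saturated group on the nitrogen, while here an aromatic ring enters, so the precedent is only partial. Compound 4 is therefore expected to show a step of a 1.3-fold higher number from compound 3 to compound 4 (0.10 log units; within the scatter), close to no change in this assay. The estimate for compound 4 is 1300 nM, with a range from 450 nM to 3800 nM.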

Compound 4, half-maximal inhibitory concentration: > 50000 nM
Compound 4: a limit, no number; the forecaster's own chance of this, stated with the estimate: 5%; at least 38-fold (1.58 log units) between middle value and limit.
By their numbers in this assay, from the lowest: compounds 1, 2 and 3 (each within the scatter of the next). At a limit, above all of these: compound 4.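

Compound 4 carries a limit of the assay and not a number: the limit of > 50000 nM in this assay, at which 1 of the 4 values shown sits. Exchanges among saturated groups on this amine nitrogen stayed within the scatter in this assay, but phenyl on the same nitrogen gives an at least 48-fold higher number from compound 3 to compound 4 (1.68 log units; beyond the scatter) and an at least 50-fold higher number from compound 2 to compound 4 (1.70 log units; beyond the scatter) and an at least 68-fold higher number from compound 1 to compound 4 (1.83 log units; beyond the scatter). The position therefore responds strongly to this one change, which the saturated groups alone did not reveal.

On these data alone, it remains open whether the aromatic ring itself or its attachment to the nitrogen accounts for this. A benzylamino group on the same chain would separate the two.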